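Swapping Hydroxy for 2-Aminophenyl on an Amide-Type Nitrogen

The source may hold more compounds than are shown below. What is called first, only, known or untested is meant among the compounds shown, and "the series" means these compounds.

In a functional assay on CT26 cells (Mus musculus) for antiproliferative activity, read by CCK-8 assay, with a stated time of 72 h (a lower number here means a stronger inhibitor of growth, a higher number a weaker inhibitor of growth), compound 1 (`Nc1nc(NCc2ccc(C(=O)NO)cc2)nc2nc(-c3ccco3)nn12`) has the entry "not determined" (no result reported), so it offers no comparison. Compound 2 (`Nc1nc(NCCCc2ccc(C(=O)NO)cc2)nc2nc(-c3ccco3)nn12`) gives > 100000 nM, which is a limit of the assay and not a number. Compound 3 (`Nc1ccccc1NC(=O)c1ccc(CCCNc2nc(N)n3nc(-c4ccco4)nc3n2)cc1`) carries 2-aminophenyl in place of hydroxy on an amide-type nitrogen. For the measured compounds named here, no measured step guides this change, so only a small shift towards stronger growth inhibition in this assay is expected, and another limit is quite possible. The estimated step of an at least 1.6-fold lower number from compound 2 to compound 3 (0.22 log units; that floor lies within the scatter) is correspondingly modest. Compound 3 is expected at 60000 nM, with an estimated range of 15000 nM to 150000 nM.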

Compound 3, concentration for 50% growth inhibition: 25200 nM
Beside the measured number, compound 3's estimate is 2.4-fold (0.38 log units) above it; measured number inside the range.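

On the amide-type nitrogen, 2-aminophenyl in place of hydroxy yields a single number in this assay, with an at least 3.9-fold lower number from compound 2 to compound 3 (0.59 log units; beyond the scatter). With the chain and the core unchanged, the group on this nitrogen alone moves the result beyond the scatter. The true size of the step stays unknown because compound 2 stands at a limit of the assay: the limit of > 100000 nM in this assay, at which 1 of the 3 values shown sits.

The compounds shown leave open how a plain phenyl or a 2-hydroxyphenyl group would read on this nitrogen, and so what the amino group of 2-aminophenyl contributes. They also leave open whether the same swap holds on the chain of compound 1.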